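Thiophene in place of methoxyphenyl on a P2Y6 agonist chain

This account rests on a few compounds, and the source may have more. Where it says the series, first, only, none or still open, it means among the compounds named here.

Measured so far in a functional assay on 1321-N1 cells for agonist activity at P2Y purinoceptor 6 (Homo sapiens), read by scintillation counting and inositol phosphate accumulation; on this read-out lower numbers stand for an effect already at smaller amounts and higher numbers for an effect only at larger amounts of compound:
- compound 1 `O=c1[nH]/c(=N\OCCCCc2ccccc2)ccn1[C@@H]1O[C@H](COP(=O)(O)OP(=O)(O)OP(=O)(O)O)[C@@H](O)[C@H]1O` gives 251 nM
- compound 2 `O=c1[nH]/c(=N\OCCCc2ccc(F)cc2)ccn1[C@@H]1O[C@H](COP(=O)(O)OP(=O)(O)OP(=O)(O)O)[C@@H](O)[C@H]1O` gives 1210 nM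
- compound 3 `COc1ccc(CCCO/N=c2/ccn([C@@H]3O[C@H](COP(=O)(O)OP(=O)(O)OP(=O)(O)O)[C@@H](O)[C@H]3O)c(=O)[nH]2)cc1` gives 277 nM

Compound 3 sits second of the three in this assay, close to compound 1 and apart from compound 2. Compound 4 `O=c1[nH]/c(=N\OCCCc2ccsc2)ccn1[C@@H]1O[C@H](COP(=O)(O)OP(=O)(O)OP(=O)(O)O)[C@@H](O)[C@H]1O` differs from it in one place: thiophen-3-yl in place of 4-methoxyphenyl on a saturated chain carbon, three bonds along the chain from an oxygen on an unsaturated carbon. Two steps at this position are known. The move from benzyl to the methoxy-bearing ring left the number essentially unchanged, a 1.1-fold higher number from compound 1 to compound 3 (0.04 log units; within the scatter), while the fluoro-bearing ring moved it up, a 4.8-fold higher number from compound 1 to compound 2 (0.68 log units; beyond the scatter). Within the data shown here, the aryl group at the chain end thus matters only modestly, and a small sulfur-containing ring has no precedent here. Compound 4 is therefore expected to stay near compound 3, a 1.4-fold higher number from compound 3 to compound 4 (0.16 log units; within the scatter), with the estimate 400 nM and a range from 150 nM to 1500 nM.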

Compound 4, half-maximal effective concentration: 164 nM
Beside the measured number, compound 4's estimate is 2.4-fold (0.39 log units) above it, within the range that was stated.
By their numbers in this assay, from the lowest: compounds 4, 1 and 3 (each within the scatter of the next); then compound 2.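

In this assay, a five-membered sulfur-containing ring at the chain end holds its place against two larger groups: thiophen-3-yl for 4-methoxyphenyl gives (a 1.7-fold lower number from compound 3 to compound 4 (0.23 log units; within the scatter)), and thiophen-3-yl for benzyl gives (a 1.5-fold lower number from compound 1 to compound 4 (0.18 log units; within the scatter)). Only the 4-fluorophenyl compound stands apart, with (a 7.4-fold lower number from compound 2 to compound 4 (0.87 log units; beyond the scatter)), so compound 2 goes against an otherwise flat position. Nothing available offers a reason for this difference.

Left open is how a furan ring, a pyridine ring or a carboxylic acid at the chain end would read, and whether a longer chain carrying thiophen-3-yl would shift the number.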